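Lengthening the amino substituent on compound 2

The source may hold more compounds than are shown below. What is called first, only, known or untested is meant among the compounds shown, and "the series" means these compounds.

Measured compounds:
compound 1, `CNC(=O)[C@H]1O[C@@H](n2cnc3c(NC)cc(C#Cc4ccc(F)s4)nc32)[C@H](O)[C@@H]1O` — 1200 nM
compound 2, `CNC(=O)[C@H]1O[C@@H](n2cnc3c(NC)nc(C#Cc4ccc(F)s4)nc32)[C@H](O)[C@@H]1O` — 1510 nM
compound 3, `CCOC(=O)[C@@]12C[C@@H]1[C@@H](n1cnc3c(NC)nc(C#Cc4ccc(F)s4)nc31)[C@H](O)[C@@H]2O` — 625 nM

All three were tested in an assay on HEK293 cells for displacement of a labelled ligand from adenosine receptor A3 (Mus musculus); a lower number here means a stronger inhibitor, a higher number a weaker inhibitor. Compound 2 gives the highest number of the three, but its gap to compound 1 lies within the scatter of this assay, so the two cannot be told apart. Compound 3 gives a clearly lower number, and that gap lies beyond the scatter.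

Compound 4, `CCCNc1nc(C#Cc2ccc(F)s2)nc2c1ncn2[C@@H]1O[C@H](C(=O)NC)[C@@H](O)[C@H]1O`, is the not yet measured compound. It differs from compound 2 in one place: ethyl in place of hydrogen on a saturated chain carbon bound to a nitrogen on an aromatic ring. In other words, the methylamino group becomes a propylamino group while the shared core and the rest of the molecule stay the same.

Going by the values given here, no pair among the measured compounds shows this particular change, so there is no measured step to lean on. The expectation is a small step, with no clear direction, and most likely not beyond the scatter; the expected step from compound 2 to compound 4 is a 1.4-fold lower number from compound 2 to compound 4 (0.14 log units; within the scatter). The estimate for compound 4 in this assay is 1100 nM, with a range from 350 nM to 3500 nM.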

Compound 4, inhibition constant: 435 nM
The estimate for compound 4 lay 2.5-fold (0.40 log units) above the measured number; low and high end bracket the measured number.
By their numbers in this assay, from the lowest: compounds 4, 3, 1 and 2 (each within the scatter of the next, the first and the last beyond it).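

In this assay, going from methylamino to propylamino gives a 3.5-fold lower number from compound 2 to compound 4 (0.54 log units; beyond the scatter), and this step lies beyond the scatter. The earlier compounds shown here all carry methylamino, so they could not show that the number responds to the length of this chain on the nitrogen. Nothing shown here accounts for the stronger binding of compound 4.

Going by these compounds, one lengthening gives only two points, so it remains open whether an ethyl chain would fall between them and whether a butyl chain would lower the number further. Also open, on these data alone, are how a branched isopropyl group or a cyclopentyl ring would behave on this nitrogen, and whether propylamino would give a similar step on the cores of compound 1 and compound 3.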